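A few compounds are considered here, and "the series" means these few. Any claim that something is new, unique, unknown or untested is made for them only; others in the source may bear on it.

Measured so far:
- compound 1, `CCc1ccccc1N(Cc1nnc(Cc2ccccc2)o1)S(=O)(=O)c1ccc(C)cc1`: 1000 nM
- compound 2, `Cc1ccc(S(=O)(=O)N(Cc2nnc(Cc3ccc(N(C)C)cc3)o2)c2cccc(Cl)c2C)cc1`: 12.6 nM

Both were run in an assay on CHO cells for displacement of a labelled ligand from prostaglandin E2 receptor EP1 subtype (Homo sapiens); on this read-out higher numbers stand for weaker inhibition and lower numbers for stronger inhibition. For the measured compounds named here, compound 2 holds the lowest number of the two; compound 1 sits well apart, beyond the scatter, though the two structures differ in more than one place and no single step links them.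

Compound 3, `Cc1ccc(S(=O)(=O)N(Cc2nnc(Cc3ccccc3Cl)o2)c2cccc(Cl)c2C)cc1`, has not yet been measured. Relative to compound 2 it carries 2-chlorophenyl in place of 4-(dimethylamino)phenyl on a saturated chain carbon bound to an aromatic carbon. Going by the values given here, nothing among the measured pairs isolates this change, so the direction can only be guessed from what compound 2 shows. The expectation is a modest move to a higher number, with the step from compound 2 to compound 3 estimated as a 3.2-fold higher number from compound 2 to compound 3 (0.50 log units; beyond the scatter), small enough that it may not clear the scatter. For compound 3 the expected value in this assay is 40 nM, with a range from 8 nM to 200 nM.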

Compound 3, half-maximal inhibitory concentration: 79.4 nM
Compound 3: the middle estimate sits 2.0-fold (0.30 log units) below what was measured; the measured number falls inside the stated range.
By their numbers in this assay, from the lowest: compound 2; then compound 3; then compound 1.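

For the compounds shown here, this is the first comparison that changes one place only, on a saturated chain carbon bound to an aromatic carbon. In this assay, 2-chlorophenyl in place of 4-(dimethylamino)phenyl gives a 6.3-fold higher number from compound 2 to compound 3 (0.80 log units; beyond the scatter), so the group in this place moves the read-out beyond the scatter, though only modestly. The 4-(dimethylamino)phenyl compound holds the lower number of this pair, and nothing at hand accounts for the step.

Going by these compounds alone, the single step changes the substituent and its ring position together, so the contributions of the dimethylamino group, the chlorine and their placement on the ring cannot be separated. Also open, going by these compounds, is how a morpholine or a carboxylic acid on that phenyl ring would read in this assay on the same core.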